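A few compounds are considered here, and "the series" means these few. Any claim that something is new, unique, unknown or untested is made for them only; others in the source may bear on it.

Measured so far in a functional assay on MCF7 cells (Homo sapiens) for cytotoxicity, read by MTT assay, with a stated time of 48 h; on this read-out higher numbers stand for weaker inhibition and lower numbers for stronger inhibition:
compound 1 `Cc1n[nH]c2c1C(c1ccc(N(C)C)cc1)C(C(=O)NN)=C(N)N2`: 42600 nM
compound 2 `Cc1n[nH]c2c1C(c1ccc(N(C)C)cc1)C(C(N)=O)=C(N)N2`: 4550 nM

Of these two, compound 2 holds the lower number, 4550 nM, and the gap to compound 1 lies beyond the scatter. Still unmeasured is compound 3 `Cc1n[nH]c2c1C(c1ccc(N(C)C)cc1)C(C(=O)O)=C(N)N2`. The change from compound 2 is hydroxy in place of amino on a carbonyl carbon, (hydroxy in place of amino on a carbonyl carbon); cut one bond further out, it reads carbamoyl to carboxy.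

Among the measured compounds shown here, only one measured step bears on this: a 9.4-fold lower number from compound 1 to compound 2 (0.97 log units; beyond the scatter). That modest step also falls within the carbonyl-bearing group, but the replacement there is on the amide-type nitrogen, not on the carbonyl carbon, so it is only a loose guide. The one other variation of this group, in compound 1, gives the higher number, 42600 nM. On that thin basis, a move to a higher number in this assay is expected, probably smaller than the measured step, and a result within the scatter remains possible. The estimated step is a 2.6-fold higher number from compound 2 to compound 3 (0.42 log units; beyond the scatter). Compound 3 is expected at 12000 nM, with an estimated range of 3000 nM to 50000 nM.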

Compound 3, half-maximal inhibitory concentration: 22000 nM
The estimate for compound 3 lay 1.8-fold (0.26 log units) below the measured number, within the range that was stated.
By their numbers in this assay, from the lowest: compound 2; then compounds 3 and 1 (each within the scatter of the next).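

In this assay, the replacement of amino by hydroxy on a carbonyl carbon gives a 4.8-fold higher number from compound 2 to compound 3 (0.68 log units; beyond the scatter) (modest, but beyond the scatter), so this position responds to a change at the carbonyl carbon itself as well as to the earlier change on the amide-type nitrogen. Compound 2, with its carbamoyl group, now stands apart from both other members of this small set, while the comparison of the remaining pair gives a 1.9-fold lower number from compound 1 to compound 3 (0.29 log units; within the scatter) (within the scatter), so compound 1 and compound 3 are not told apart in this assay. No measurement in hand accounts for either step.

Still open, on these data alone, is how this place responds to a methyl ester, a nitrile or a secondary amide such as the methyl amide, any of which would show whether the carbamoyl group is a special case or one of several workable groups. Also open, as far as these compounds go, is whether the advantage of compound 2 carries over to other cell lines or to other groups on the shared core.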